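Notes on the end group of compound 2

The source may hold more compounds than are shown below. What is called first, only, known or untested is meant among the compounds shown, and "the series" means these compounds.

Measured so far in a functional assay on MCF7 cells (Homo sapiens) for antiproliferative activity, read by MTT assay, with a stated time of 48 h; on this read-out higher numbers stand for weaker inhibition and lower numbers for stronger inhibition
- compound 1 `COc1cc(CNC(=O)CCCCCCC(C)C)ccc1OC(=O)CCC(=O)Oc1ccc(-c2cc(=S)ss2)cc1` gives 2560 nM
- compound 2 `COc1cc(CNC(=O)CCCC/C=C/C(C)C)ccc1OC(=O)CCC(=O)Oc1ccc(-c2cc(=S)ss2)cc1` gives 2120 nM

Among the compounds with values here, compound 2 has no measured neighbour outside the scatter: the only step available is a 1.2-fold lower number from compound 1 to compound 2 (0.08 log units; within the scatter) in the chain. Compound 3 `COc1cc(CNC(=O)CCCC/C=C/C(C)C)ccc1OC(=O)CCC(=O)Oc1ccc(C(N)=S)cc1` differs from compound 2 by a group of 3 heavy atoms (1 carbon, 1 nitrogen, 1 sulfur; no ring) in place of a group of 6 heavy atoms (3 carbon, 3 sulfur; one five-membered aromatic ring with 2 hetero atoms), on an aromatic carbon on an aromatic carbon of a six-membered aromatic ring of carbon only, para to a large group. The chain step lies elsewhere in the molecule and sets no size or direction for this change. Within the data shown here, no measured step bears on this place, so only a modest move towards a higher number is assumed in this assay and the margins stay wide. The expected move is a 1.7-fold higher number from compound 2 to compound 3 (0.22 log units; within the scatter) at this stage. For compound 3 the estimated value is 3500 nM with an expected range from 1000 nM to 12000 nM in this estimate.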

Compound 3, half-maximal inhibitory concentration: > 50000 nM
Compound 3 ended at the assay's limit (the forecaster's own chance of this, stated with the estimate: 5%); at least 14-fold (1.15 log units) between middle value and limit.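

Within the data shown here, the aromatic carbon para to a large group is the first place where a change reads beyond the scatter: in this assay the step is an at least 23-fold higher number from compound 2 to compound 3 (1.37 log units; beyond the scatter). Compound 3 stands at a limit of the assay and not at a number, so the step has a lower bound only: the limit of > 50000 nM in this assay, at which 1 of the 3 values shown sits. The chain change, by contrast, gave a 1.2-fold lower number from compound 1 to compound 2 (0.08 log units; within the scatter), so the group of 6 heavy atoms with its five-membered aromatic ring matters more in this series than the end of the chain.

This single step changes the ring, the sulfur count and the hydrogen-bond donor count together, and it does not separate them. From the compounds shown here alone, how an amine or a carboxylic acid at this place would read remains open.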